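Extending the chain between carbonyl and phenyl ring

The compounds below may be only part of what the source reports. "The series", "measured", "known", "first", "only" and "open" are said of these compounds alone.

Measured so far:
compound 1 `Cn1cc(C(=O)CCCCc2ccccc2)cc1/C=C/C(=O)NO` gives 110 nM
compound 2 `Cn1cc(C(=O)CCCCCc2ccccc2)cc1/C=C/C(=O)NO` gives 70.8 nM

Two compounds share the same core and differ only in the length of the saturated chain that links a carbonyl to a phenyl ring. In an assay on isolated protein for inhibition of histone deacetylase HD2 (Zea mays) (a lower number here means a stronger inhibitor, a higher number a weaker inhibitor), compound 1 gives 110 nM and compound 2 gives 70.8 nM. Compound 2 has the lowest of the two numbers; its nearest neighbour is compound 1, and the step of a 1.6-fold lower number from compound 1 to compound 2 (0.19 log units; within the scatter) lies within the scatter, so the two cannot be told apart with confidence.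

Compound 3 `Cn1cc(C(=O)CCCCCCc2ccccc2)cc1/C=C/C(=O)NO` has not yet been measured. It differs from compound 2 by benzyl in place of phenyl on a saturated chain carbon, five bonds along the chain from a carbonyl carbon. Going by the values given here, this is the same kind of change as the one already seen from compound 1 to compound 2, only one bond further along the chain. Among the compounds with values here, the one step that bears on it, a 1.6-fold lower number from compound 1 to compound 2 (0.19 log units; within the scatter), was small and within the scatter. A similarly small step is therefore expected, a 1.2-fold lower number from compound 2 to compound 3 (0.07 log units; within the scatter), or none beyond the scatter. Compound 3 is expected to give about 60 nM, with a range from 25 nM to 150 nM.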

Compound 3, half-maximal inhibitory concentration: 263 nM
Estimate against measurement, compound 3: 4.4-fold (0.64 log units) below; the whole stated range lies below it.
By their numbers in this assay, from the lowest: compounds 2 and 1 (each within the scatter of the next); then compound 3.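

In this assay, chain length turns out to matter at this position, which the earlier pair could not show. Phenyl replaced by benzyl on a saturated chain carbon, five bonds along the chain from a carbonyl carbon, gives a 3.7-fold higher number from compound 2 to compound 3 (0.57 log units; beyond the scatter), whereas the same kind of change one bond nearer the carbonyl made no difference that could be told from the scatter. Compared with the shorter chain of compound 1, phenethyl in place of phenyl gives a 2.4-fold higher number from compound 1 to compound 3 (0.38 log units; beyond the scatter), so compound 3 is the weakest of the three inhibitors, and among these compounds added length is tolerated only up to the chain of compound 2.

Nothing available here offers a reason for this loss of inhibition. Still open, on these data alone, are whether a longer chain than that of compound 3 would weaken inhibition further, whether a shorter chain than that of compound 1 would keep it, and whether an amine or a carboxylic acid in place of the phenyl ring would alter how chain length affects the number.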